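A few compounds are considered here, and "the series" means these few. Any claim that something is new, unique, unknown or untested is made for them only; others in the source may bear on it.

Measured so far in a functional assay on A549 cells (Homo sapiens) for cytotoxicity, read by MTT assay; a higher number here means a weaker inhibitor, a lower number a stronger inhibitor:
compound 1 `CCOC(=O)C12C(=O)OCC=C1COC2c1ccc(Cl)cc1`: > 1000000 nM, a limit of the assay
compound 2 `CCOC(=O)C12C(=O)OCC=C1COC2c1ccc(OC)cc1`: 9300 nM
compound 3 `CCOC(=O)C12C(=O)OCC=C1COC2c1ccc(OC)c(OC)c1`: > 1000000 nM, a limit of the assay

Compound 3 stands at the limit, which is where the limit of > 1000000 nM in this assay, at which 2 of the 3 values shown sit, places it together with compound 1; only compound 2 gives a number. The step to compound 4 `CCOC(=O)C12C(=O)OCC=C1COC2c1cc(OC)c(OC)c(OC)c1` is methoxy in place of hydrogen on an aromatic carbon. The step that bears on it most directly is an at least 100-fold higher number from compound 2 to compound 3 (2.03 log units; beyond the scatter), the same kind of change and large; an at least 100-fold lower number from compound 1 to compound 2 (2.03 log units; beyond the scatter) ran the other way with a different group. Going by the values given here, no compound with three methoxy groups has been measured. Compound 4 is therefore expected to stay at or near the limit, estimated at 700000 nM (range 50000 nM to 1000000 nM), meaning an expected step of an at least 1.4-fold lower number from compound 3 to compound 4 (0.15 log units; that floor lies within the scatter).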

Compound 4, half-maximal inhibitory concentration: 13300 nM
Beside the measured number, compound 4's estimate is 53-fold (1.72 log units) above it; the whole stated range lies above it.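

The same replacement, methoxy in place of hydrogen on an aromatic carbon, now runs the other way: an at least 100-fold higher number from compound 2 to compound 3 (2.03 log units; beyond the scatter) stands against an at least 75-fold lower number from compound 3 to compound 4 (1.87 log units; beyond the scatter). Placed ortho to a methoxy group, the new methoxy returns the series to a measured number in this assay, so this change has no single direction across these compounds. Only compound 1 and compound 3 remain at a limit of the assay: the limit of > 1000000 nM in this assay, at which 2 of the 4 values shown sit. Still open, as far as these compounds go, is whether an amine or a hydroxy group in this place also gives a measured number, and whether a carboxylic acid in place of the ethyl ester keeps one.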